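The source may hold more compounds than are shown below. What is called first, only, known or untested is meant among the compounds shown, and "the series" means these compounds.

The series shares a sulfonamide-bearing biaryl carrying a chloro, fluorobenzyloxy-substituted aniline, and is examined in a toxicity assay on HepG2 cells (Homo sapiens) for cytotoxicity, read by MTT assay, with a stated time of 48 h; on this read-out higher numbers stand for lower toxicity in this test and lower numbers for higher toxicity in this test. Compound 1 `CN1CCN(S(=O)(=O)c2ccc(-c3ccc4c(Nc5ccc(OCc6cccc(F)c6)c(Cl)c5)cnnc4c3)cc2)CC1` carries a 4-methylpiperazin-1-yl group on the sulfonyl sulfur. In this assay compound 1 reaches only the limit of > 15 uM, a boundary of the measurement rather than a number. Compound 2 `CN1CCCN(S(=O)(=O)c2ccc(-c3ccc4c(Nc5ccc(OCc6cccc(F)c6)c(Cl)c5)cnnc4c3)cc2)CC1` differs by the change (4-methylpiperazin-1-yl in place of 4-methyl-1,4-diazepan-1-yl on a sulfonyl sulfur), and in this assay compound 2 gives 15 uM. The step of a number no lower from compound 2 to compound 1 (the limit leaves the size open) is therefore open in size, since one side of it is a limit.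

Compound 3 `CN1CCCN(S(=O)(=O)c2ccc(-c3ccc4ccnc(Nc5ccc(OCc6cccc(F)c6)c(Cl)c5)c4c3)cc2)CC1` carries the 4-methyl-1,4-diazepan-1-yl group of compound 2 on a different core; how the two cores differ is not broken down here. In this assay compound 3 also stops at the limit of > 15 uM, which is a boundary and not a number.

Compound 4 `CN1CCN(S(=O)(=O)c2ccc(-c3ccc4ccnc(Nc5ccc(OCc6cccc(F)c6)c(Cl)c5)c4c3)cc2)CC1` carries the core of compound 3 and differs from it by 4-methylpiperazin-1-yl in place of 4-methyl-1,4-diazepan-1-yl on a sulfonyl sulfur, the same change as that from compound 2 to compound 1, made at the same place. Its value in this assay is awaited. The step that the limit leaves unreadable from compound 3 to compound 4 is expected to be at most small, because the limit of > 15 uM in this assay, at which 2 of the 3 values shown sit, shows that two of the three values already sit at the boundary and because a number no lower from compound 2 to compound 1 (the limit leaves the size open) moved no lower. Compound 4 is estimated at 20 uM, with a range from 10 uM to 50 uM, and most probably it will also be reported only as a limit.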

Compound 4, half-maximal toxic concentration: > 15 uM
Compound 4 gave a limit, no number; the forecaster's own chance of this, stated with the estimate: 80%; the middle value does not contradict the limit.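

In this assay no new step can be read: compound 3 and compound 4 both stop at a limit, so the change to 4-methylpiperazin-1-yl from 4-methyl-1,4-diazepan-1-yl has no readable size on this core. The compounds shown leave open how far compound 1, compound 3 and compound 4 lie beyond that boundary, since most values rest there: the limit of > 15 uM in this assay, at which 3 of the 4 values shown sit.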